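The compounds below may be only part of what the source reports. "The series", "measured", "known", "first", "only" and "open" are said of these compounds alone.

In a functional assay on MCF7 cells (Homo sapiens) for antiproliferative activity, read by MTT assay, with a stated time of 72 h (on this read-out higher numbers stand for weaker inhibition and lower numbers for stronger inhibition), compound 1 (`FC(F)(F)c1ccc(COc2cccc(Nc3ncnc4cc5c(cc34)OCCOCCO5)c2)cc1`) gives > 100000 nM as a limit of the assay and not a number. Going by the values given here, compound 2 (`O=[N+]([O-])c1ccc(COc2cccc(Nc3ncnc4cc5c(cc34)OCCOCCO5)c2)cc1`) gives 42400 nM as the only true number so far, and so it cannot yet be ranked against another measured value. Among the compounds with values here, the one measured step is an at least 2.3-fold lower number from compound 1 to compound 2 (0.37 log units; beyond the scatter) and it bounds the change without fixing its size, with the limit of > 100000 nM in this assay, at which 1 of the 2 values shown sits, as its other end. Compound 3 (`c1ccc(COc2cccc(Nc3ncnc4cc5c(cc34)OCCOCCO5)c2)cc1`) takes the step further at the same place, with hydrogen in place of nitro on an aromatic carbon, para to a large group (hydrogen in place of nitro on an aromatic carbon) and 4-nitrobenzyl becoming benzyl. Within the data shown here, no measured step removes a group outright, so the step from trifluoromethyl to nitro bears on it only indirectly. It shows that this place can move the number, and compound 2 stands at 42400 nM. A small move towards a higher number is therefore expected, not clearly beyond the scatter, and the estimate is a 1.4-fold higher number from compound 2 to compound 3 (0.15 log units; within the scatter) in this assay as the expected change. For compound 3 the estimated value is 60000 nM with an expected lower end of 20000 nM and an expected upper end of 150000 nM as its range.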

Compound 3, half-maximal inhibitory concentration: 40900 nM
Beside the measured number, compound 3's estimate is 1.5-fold (0.17 log units) above it, and the stated range covers the measured number.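

In this assay, the step of a 1.0-fold lower number from compound 2 to compound 3 (0.02 log units; within the scatter) shows that nitro on this aromatic carbon, para to a large group, can give way to hydrogen with no change that stands out from the scatter, so 4-nitrobenzyl and benzyl cannot be told apart here. This gives the series its plain benzyloxy reference, which the earlier pair lacked, and the step of an at least 2.4-fold lower number from compound 1 to compound 3 (0.38 log units; beyond the scatter) sets trifluoromethyl apart from hydrogen as well as from nitro, so that among these three groups only trifluoromethyl goes with a higher number. Compound 1 remains a limit of the assay and not a number, so this step too has a bound and no fixed size: the limit of > 100000 nM in this assay, at which 1 of the 3 values shown sits.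

The compounds shown leave open whether any group at this place, such as an amine or a carboxylic acid, would take the number clearly below the values of compound 2 and compound 3. They also leave open how a longer chain in place of the benzyloxy link would read, and how far compound 1 truly lies from the other two.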